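A few compounds are considered here, and "the series" means these few. Any claim that something is new, unique, unknown or untested is made for them only; others in the source may bear on it.

Two cores are compared in a functional assay on HCT-116 cells (Homo sapiens) for antiproliferative activity, read by MTT assay, with a stated time of 72 h; on this read-out lower numbers stand for stronger inhibition of growth and higher numbers for weaker inhibition of growth. Compound 1 `Clc1ccc(Nc2nc3ncccc3n2Cc2ccccc2)cc1` gives 59500 nM and compound 2 `Clc1cccc(Nc2nc3ncccc3n2Cc2ccccc2)c1` gives 36300 nM; the change between them, (3-chlorophenyl in place of 4-chlorophenyl on a nitrogen on an aromatic ring), made the step of a 1.6-fold lower number from compound 1 to compound 2 (0.21 log units; within the scatter). Compound 3 `Cn1nc(-c2ccnc(Nc3ccc(Cl)cc3)n2)c2ccccc21` has a different core; how the two cores differ is not broken down here. In this assay compound 3 gives 8730 nM, the lowest of the three numbers, with the gaps to compound 2 and compound 1 both beyond the scatter. Compound 4 `Cn1nc(-c2ccnc(Nc3cccc(Cl)c3)n2)c2ccccc21` is not yet measured; it carries the same change on the core of compound 3, (3-chlorophenyl in place of 4-chlorophenyl on a nitrogen on an aromatic ring), at the same place as before. Going by the values given here, the step from compound 3 to compound 4 is expected to be a 1.6-fold lower number from compound 3 to compound 4 (0.20 log units; within the scatter), resting only on the single earlier step of a 1.6-fold lower number from compound 1 to compound 2 (0.21 log units; within the scatter), which was small. The estimate for compound 4 is therefore 5500 nM, expected between 2500 nM and 15000 nM.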

Compound 4, concentration for 50% growth inhibition: 6400 nM
For compound 4 the middle estimate is 1.2-fold (0.07 log units) below the measured one; the measured number falls inside the stated range.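

On the core of compound 3, 3-chlorophenyl in place of 4-chlorophenyl gives a 1.4-fold lower number from compound 3 to compound 4 (0.13 log units; within the scatter) in this assay. Set beside the step on the other core, the two agree: the same change on two cores in this assay, a 1.6-fold lower number (0.21 log units; within the scatter) from compound 1 to compound 2 and a 1.4-fold lower number (0.13 log units; within the scatter) from compound 3 to compound 4, 1.2-fold (0.08 log units) apart, within the scatter of two such steps. So the change carries across these two cores as a small step that cannot be told from the scatter on either one; this does not show that the change has a real effect on growth inhibition, and two cores set no rule for the wider series.

Still open, going by these compounds, is whether a group other than chlorine on the phenyl ring, such as an amine or a carboxylic acid, would give a step beyond the scatter. Also open, on these data alone, is whether such a step would carry from one core to the other.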